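A few compounds are considered here, and "the series" means these few. Any claim that something is new, unique, unknown or untested is made for them only; others in the source may bear on it.

In an ADME assay on the whole organism (Rattus norvegicus) for pharmacokinetics, at a dose of 10 mg/kg by the oral route (on this read-out lower numbers stand for lower exposure and higher numbers for higher exposure at the dose given), compound 1 `NC(=O)c1cc(Cl)c2c(Cl)c(C#CC3CCOCC3)n([C@H]3CCCNC3)c2n1` gives 216 nM, and compound 2 `COCCC#Cc1c(Cl)c2c(Cl)cc(C(N)=O)nc2n1[C@H]1CCCNC1` gives 233 nM. Within the data shown here, the one measured step, a 1.1-fold higher number from compound 1 to compound 2 (0.03 log units; within the scatter), shows that swapping a ring for an open chain on the triple-bonded carbon left this assay essentially unchanged. Compound 2 thus stands with a number that cannot be told apart from that of compound 1. Compound 3 `NC(=O)c1cc(Cl)c2c(Cl)c(C#CC3CCCO3)n([C@H]3CCCNC3)c2n1` carries oxolan-2-yl in place of 2-methoxyethyl on a triple-bonded carbon, bringing a ring back at the same spot. Because a 1.1-fold higher number from compound 1 to compound 2 (0.03 log units; within the scatter) showed no shift beyond the scatter, the expected step of a 1.1-fold lower number from compound 2 to compound 3 (0.02 log units; within the scatter) is likewise none beyond the scatter. Compound 3 is therefore estimated at 220 nM, with a range from 90 nM to 520 nM.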

Compound 3, maximal plasma concentration: 133 nM
Beside the measured number, compound 3's estimate is 1.7-fold (0.22 log units) above it, within the range that was stated.
By their numbers in this assay, from the lowest: compounds 3, 1 and 2 (each within the scatter of the next).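

At the triple-bonded carbon, this assay separates none of the three groups seen so far: oxolan-2-yl for 2-methoxyethyl gives a 1.8-fold lower number from compound 2 to compound 3 (0.24 log units; within the scatter), and oxolan-2-yl for oxan-4-yl gives a 1.6-fold lower number from compound 1 to compound 3 (0.21 log units; within the scatter). A second ring of a different size therefore joins the first ring and the open chain, all within the scatter of one another. Nothing at hand offers a reason for these numbers. Still open, as far as these compounds go, is whether an amine, a carboxylic acid or a longer chain on this carbon would shift the number beyond the scatter.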